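The compounds below may be only part of what the source reports. "The series", "measured", "known", "first", "only" and "open" are said of these compounds alone.

Compound 1 `O=C1OCC=C1CSC(=S)NC1CC1` and compound 2 `CNC(=S)SCC1=CCOC1=O` share one core and differ only in the group on an amide-type nitrogen. In a functional assay on HeLa cells (Homo sapiens) for antiproliferative activity, read by MTT assay, with a stated time of 72 h (a lower number here means a stronger inhibitor, a higher number a weaker inhibitor), compound 1 gives 24100 nM, and compound 2 gives 36100 nM. The step between them, methyl in place of cyclopropyl, is a 1.5-fold higher number from compound 1 to compound 2 (0.18 log units; within the scatter), so the two compounds cannot be told apart on these numbers, and compound 2 has no settled place other than beside compound 1.

Compound 3 `CC(C)NC(=S)SCC1=CCOC1=O` follows from compound 2 by the change (isopropyl in place of methyl on an amide-type nitrogen). Among the compounds with values here, the only step that bears on it is the one from compound 1 to compound 2, which stayed within the scatter, so the account expects no movement beyond the scatter in this assay for compound 3 either, a step of about a 1.3-fold lower number from compound 2 to compound 3 (0.11 log units; within the scatter). Compound 3 is therefore estimated at 28000 nM, with a range from 12000 nM to 65000 nM.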

Compound 3, half-maximal inhibitory concentration: 137000 nM
Compound 3: middle estimate off by 4.9-fold (0.69 log units), on the low side; measured number outside the range, above it.
By their numbers in this assay, from the lowest: compounds 1 and 2 (each within the scatter of the next); then compound 3.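

On the amide-type nitrogen, whose other neighbour is the thiocarbonyl carbon, the choice of group proves able to shift the number in this assay: isopropyl in place of methyl gives a 3.8-fold higher number from compound 2 to compound 3 (0.58 log units; beyond the scatter) and isopropyl in place of cyclopropyl gives a 5.7-fold higher number from compound 1 to compound 3 (0.75 log units; beyond the scatter) in the same direction. Within the data shown here, the position is therefore not indifferent to change, as the pair of compound 1 and compound 2 alone might have suggested, and isopropyl is the one group of the three that stands apart. No measurement shown here accounts for this separation.

The compounds shown leave open whether a longer chain such as n-propyl, or a tert-butyl or phenyl group, on this nitrogen would sit with compound 3 or with compound 1 and compound 2. They also leave open whether isopropyl would have the same effect on a core other than the shared one.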